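From a basic amine to a fluorophenoxy tail

A few compounds are considered here, and "the series" means these few. Any claim that something is new, unique, unknown or untested is made for them only; others in the source may bear on it.

Compound 1 `COc1ccc(-c2cc(=O)c3c(OC)cc(OC)cc3n2S(=O)(=O)c2ccc(C)cc2)cc1` carries an entry of "not determined" (no result reported) in a functional assay on SEM cells (Homo sapiens) for antiproliferative activity, with a stated time of 72 h; on this read-out lower numbers stand for an effect already at smaller amounts and higher numbers for an effect only at larger amounts of compound. Compound 2 `COc1cc(OC)c2c(=O)cc(C(=O)Nc3ccc(N4CCN(C)CC4)cc3)[nH]c2c1` gives > 19800 nM in this assay, and this is a limit of the assay rather than a number (the limit of > 19800 nM in this assay, at which 1 of the 2 values shown sits). Compound 3 `COc1cc(OC)c2c(=O)cc(C(=O)Nc3ccc(Oc4ccc(F)cc4)cc3)[nH]c2c1` differs from compound 2 by 4-fluorophenoxy in place of 4-methylpiperazin-1-yl on an aromatic carbon; the new group sits para to a large group. Going by the values given here, with no measured step to lean on, the expected step of an at least 2.2-fold lower number from compound 2 to compound 3 (0.34 log units; beyond the scatter) is a modest shift toward lower values, possibly still within the scatter. Compound 3 is therefore estimated at 9000 nM, between 1500 nM and 40000 nM.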

Compound 3, half-maximal effective concentration: > 50000 nM
Compound 3 was reported as a limit; the forecaster's own chance of this, stated with the estimate: 45%; at least 5.5-fold (0.74 log units) between middle value and limit.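

Going by these compounds alone, the results for compound 2 and compound 3 are both limits, and no step between them can be read. The compounds shown leave open what actual number either would give, and whether 4-fluorophenoxy in place of 4-methylpiperazin-1-yl shifts it at all.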